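A few compounds are considered here, and "the series" means these few. Any claim that something is new, unique, unknown or untested is made for them only; others in the source may bear on it.

Compound 1 `Cc1cc(C(=O)O)ccc1OCCCCOc1ccc(C(=O)CC2CCCC2)c(O)c1C`: > 10000 nM
Compound 2 `Cc1ccc(C(=O)O)cc1OCCCCOc1ccc(C(=O)CC2CCCC2)c(O)c1C`: > 10000 nM

In an assay on HEK293 cells for positive allosteric modulation of metabotropic glutamate receptor 3 (Rattus norvegicus), read by thallium flux, with a stated time of 2.5 min (on this read-out higher numbers stand for an effect only at larger amounts of compound and lower numbers for an effect already at smaller amounts), compound 1 gives > 10000 nM, which is a limit of the assay and not a number. Compound 2 gives > 10000 nM in this assay, again a limit. Among the compounds with values here, the single measured step, a step that the two limits leave unreadable from compound 1 to compound 2, is therefore unreadable, since (the limit of > 10000 nM in this assay, at which 2 of the 2 values shown sit).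

Compound 3 `Cc1c(OCCCCOc2cccc(C(=O)O)c2)ccc(C(=O)CC2CCCC2)c1O` differs from compound 2 by hydrogen in place of methyl on an aromatic carbon. Within the data shown here, no measured step touches this change: the one step known involves a different pair of positions, and its size is hidden by the two limits. Compound 2 itself stands only at a limit in this assay. With nothing pointing to a readable gain, compound 3 is expected to stay where compound 2 is, so the estimated step is a step that the limit leaves unreadable from compound 2 to compound 3. The estimate for compound 3 in this assay is 15000 nM, with a range from 4000 nM to 60000 nM, and a limit rather than a number is thought the most likely outcome.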

Compound 3, half-maximal effective concentration: 3400 nM
For compound 3 the middle estimate is 4.4-fold (0.64 log units) above the measured one, and the stated range ends above it.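

In this assay, the methyl group on the aromatic carbon para to the carboxy group turns out to matter: hydrogen in its place brings an at least 2.9-fold lower number from compound 2 to compound 3 (0.46 log units; beyond the scatter). Within the same series, 3-carboxyphenyl in place of 4-carboxy-2-methylphenyl brings an at least 2.9-fold lower number from compound 1 to compound 3 (0.46 log units; beyond the scatter), so this ring without the methyl is the only one shown that gives a value rather than a limit. Both steps are lower bounds only, since their starting compounds sit at a limit: the limit of > 10000 nM in this assay, at which 2 of the 3 values shown sit.

The compounds shown leave open whether a 4-carboxyphenyl group without the methyl would read like compound 3, and whether a fluorine or a methoxy group in place of the methyl would do the same. They also leave open how a tetrazole in place of the carboxylic acid, or a longer chain linking the two aromatic parts, would read in this assay.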